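Anilino versus cyclohexylamino on a pyranone-free core comparison

A few compounds are considered here, and "the series" means these few. Any claim that something is new, unique, unknown or untested is made for them only; others in the source may bear on it.

Measured so far:
compound 1 `O=c1cc(NC2CCCCC2)cc(/C=C/c2ccccc2)o1` — 1.25 uM
compound 2 `COc1cccc(Nc2cc(-c3ccccc3)oc(=O)c2)c1` — 0.63 uM
compound 3 `CCCCCc1cc(Nc2ccc(OC)cc2)cc(=O)o1` — 4.42 uM

Of the compounds shown here, three have been tested in a functional assay on A549 cells (Homo sapiens) for cytotoxicity, read by MTT assay, with a stated time of 72 h; on this read-out lower numbers stand for an effect already at smaller amounts and higher numbers for an effect only at larger amounts of compound. Compound 1 gives 1.25 uM, which places it second highest among the three numbers. Its nearest neighbour is compound 2 with 0.63 uM, a gap that lies within the usual scatter, so no order between compound 1 and compound 2 can be claimed. Its furthest neighbour is compound 3 with 4.42 uM, a gap that lies beyond the scatter, with compound 3 needing the larger amount.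

Compound 4 `COc1ccc(Nc2cc(/C=C/c3ccccc3)oc(=O)c2)cc1` has not yet been measured in this assay. It differs from compound 1 in one place: 4-methoxyphenyl in place of cyclohexyl on a nitrogen on an aromatic ring. Going by the values given here, no two measured compounds differ from each other in a single place, so no directly comparable step exists. Compound 2 and compound 3 both carry a methoxyphenyl group on the same nitrogen and sit on either side of compound 1, which gives no consistent direction for this exchange.

Compound 4 is therefore expected to land close to compound 1, the expected step being a 1.2-fold higher number from compound 1 to compound 4 (0.08 log units; within the scatter), not beyond the scatter. The estimate for compound 4 is 1.5 uM, in the range 0.5 uM to 4.5 uM.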

Compound 4, concentration for half-maximal effect: 0.11 uM
The estimate for compound 4 lay 14-fold (1.13 log units) above the measured number; the whole stated range lies above it.
By their numbers in this assay, from the lowest: compound 4; then compounds 2 and 1 (each within the scatter of the next); then compound 3.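

In this assay, going by these compounds alone, the group on the nitrogen proves to matter on this core: with the 2-phenylethenyl group held fixed, 4-methoxyphenyl in place of cyclohexyl gives an 11-fold lower number from compound 1 to compound 4 (1.06 log units; beyond the scatter), the first reading of a single change at this nitrogen. The aromatic carbon also responds to a single change: with 4-methoxyphenyl kept on the nitrogen, 2-phenylethenyl in place of pentyl gives a 40-fold lower number from compound 3 to compound 4 (1.60 log units; beyond the scatter). Both steps lie beyond the scatter and both end in a lower number at compound 4, so neither place is indifferent to the group it carries, and the pairing of 4-methoxyphenyl with 2-phenylethenyl gives a lower number than either single-place partner.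

No measurement is available that accounts for either step. Going by these compounds, it remains open whether the methoxy group contributes to the step at the nitrogen or the aromatic ring alone suffices, and how an unsubstituted phenyl or a benzyl group on that nitrogen would compare with 4-methoxyphenyl.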